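Nitrogen substituent survey toward compound 4

The compounds below may be only part of what the source reports. "The series", "measured", "known", "first", "only" and "open" are said of these compounds alone.

Measured so far in a functional assay (trachea) with Cavia porcellus as the target; on this read-out lower numbers stand for stronger inhibition and higher numbers for weaker inhibition:
compound 1 `CC(C)n1nc(-c2cccnc2)c2ccccc2c1=O`: 3090 nM
compound 2 `O=c1c2ccccc2c(-c2cccnc2)nn1C1CCCC1`: 2750 nM
compound 3 `O=c1c2ccccc2c(-c2cccnc2)nn1CC1CCCCC1`: 209 nM

Compound 3 gives the lowest number of the three, with a 15-fold lower number from compound 1 to compound 3 (1.17 log units; beyond the scatter) and a 13-fold lower number from compound 2 to compound 3 (1.12 log units; beyond the scatter), while a 1.1-fold lower number from compound 1 to compound 2 (0.05 log units; within the scatter). The next compound, compound 4 `O=c1c2ccccc2c(-c2cccnc2)nn1CCSc1ncccn1`, changes the group on the chain bound to the aromatic nitrogen: ((pyrimidin-2-yl)sulfanyl)methyl in place of cyclohexyl on a saturated chain carbon bound to an aromatic nitrogen. Among the compounds with values here, the two large steps onto compound 3 show that this position moves this assay strongly, but no measured step replaces a carbon ring with an aromatic heterocycle bearing sulfur, so their direction cannot be carried over. A step back toward the weaker compounds is expected, a 4.8-fold higher number from compound 3 to compound 4 (0.68 log units; beyond the scatter), with wide uncertainty. Compound 4 is estimated at 1000 nM, range 200 nM to 5000 nM.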

Compound 4, half-maximal inhibitory concentration: 11000 nM
Compound 4: the middle estimate sits 11-fold (1.04 log units) below what was measured; measured number outside the range, above it.
By their numbers in this assay, from the lowest: compound 3; then compounds 2 and 1 (each within the scatter of the next); then compound 4.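

In this assay, within the data shown here, ((pyrimidin-2-yl)sulfanyl)methyl in place of cyclohexyl gives a 53-fold higher number from compound 3 to compound 4 (1.72 log units; beyond the scatter), so this position can raise the number sharply, whereas the earlier steps here only lowered it or stayed within the scatter. The low number of compound 3 therefore does not survive this change of group on the saturated chain carbon. Nothing available here explains the rise. From the compounds shown here alone, it remains open whether the sulfur or the pyrimidine ring accounts for the step. A phenylsulfanyl group on the same chain would separate the two.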